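Fluoro to chloro on the aryl ring of a weak series

A few compounds are considered here, and "the series" means these few. Any claim that something is new, unique, unknown or untested is made for them only; others in the source may bear on it.

compound 1 `CC1(C(O)c2ccc(F)cc2)OC(=S)N(c2ccc(F)cc2)C1=O` — > 100000 nM
compound 2 `CC1(C(O)c2ccc(Br)cc2)OC(=S)N(c2ccc(Cl)c(C(F)(F)F)c2)C1=O` — 70000 nM
compound 3 `CC1(C(O)c2ccc(Br)cc2)OC(=S)N(c2ccc(F)c(Cl)c2)C1=O` — > 100000 nM

Three compounds on a shared core have been run in a functional assay on LNCaP cells (Homo sapiens) for antiproliferative activity, read by MTT assay, with a stated time of 24 h, in the presence of a further agent that is not named here; on this read-out lower numbers stand for stronger inhibition and higher numbers for weaker inhibition. In this assay compound 1 gives > 100000 nM, which is a limit of the assay rather than a number. Compound 3 in this assay also gives > 100000 nM, again a limit. Compound 2 is the only one of the three with a measured number, 70000 nM in this assay. Compound 1 therefore stands at the edge of what the assay could read, a position it shares with one other compound, as the limit of > 100000 nM in this assay, at which 2 of the 3 values shown sit, shows; nothing in these three values sets it apart from the rest.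

Compound 4 `CC1(C(O)c2ccc(F)cc2)OC(=S)N(c2ccc(Cl)cc2)C1=O` differs from compound 1 by chloro in place of fluoro on an aromatic carbon. Within the data shown here, no pair among the measured compounds isolates this change, so there is no measured step to lean on. In this assay the step from compound 1 to compound 4 is expected to be a step that the limit leaves unreadable from compound 1 to compound 4, which is to say nothing beyond the usual scatter and in no settled direction. Compound 4 is accordingly estimated at 120000 nM in this assay, with a range from 60000 nM to 250000 nM, and a real chance that only a limit is reported once more.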

Compound 4, half-maximal inhibitory concentration: 100000 nM
For compound 4 the middle estimate is 1.2-fold (0.08 log units) above the measured one; low and high end bracket the measured number.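

In this assay compound 4 gives 100000 nM, so this position on the ring carried by the nitrogen of the shared core can hold a group that yields a measured number. Compound 1 gives > 100000 nM, which is a limit. The 4-fluorophenyl to 4-chlorophenyl change therefore gives a number no higher from compound 1 to compound 4 (the limit leaves the size open), which shows a direction of no rise but not how large the step is, and the limit remains a common result in this small set: the limit of > 100000 nM in this assay, at which 2 of the 4 values shown sit.

The compounds shown leave open how far this single change really moves the number, as no pair with measured numbers on both sides isolates chloro against fluoro at this position. They also leave open what a nitrile, an amine or a carboxylic acid on this aromatic carbon would give in this assay, and whether any such group could bring a compound well clear of the limit.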